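Carbamate series: second methoxy on the phenethyl ring

This account rests on a few compounds, and the source may have more. Where it says the series, first, only, none or still open, it means among the compounds named here.

compound 1 `COc1ccc(CCOC(=O)N(c2ccccc2)C2CN3CCC2CC3)cc1`: 230 nM
compound 2 `COc1ccc(COC(=O)N(c2ccccc2)C2CN3CCC2CC3)cc1OC`: 550 nM
compound 3 `Cc1ccc(COC(=O)N(c2ccccc2)C2CN3CCC2CC3)cc1F`: 30 nM

In an assay on CHO cells for displacement of a labelled ligand from muscarinic acetylcholine receptor M5 (Homo sapiens), read by scintillation counting, with a stated time of 2 h (a lower number here means a stronger inhibitor, a higher number a weaker inhibitor), compound 1 gives 230 nM, the second highest of the three numbers; compound 2 gives 550 nM and compound 3 gives 30 nM. Within the data shown here, the only single-place step measured, a 7.7-fold lower number from compound 1 to compound 3 (0.88 log units; beyond the scatter), exchanges the whole aryl group and does not bear on the present change. Compound 4 `COc1ccc(CCOC(=O)N(c2ccccc2)C2CN3CCC2CC3)cc1OC` differs from compound 1 by methoxy in place of hydrogen on an aromatic carbon. Among the measured compounds shown here, no measured pair isolates this change; compound 2 carries the same two methoxy groups on a shorter chain, and its number stands higher than that of compound 1. The step of a 1.5-fold higher number from compound 1 to compound 4 (0.18 log units; within the scatter) is therefore expected to be small, if anything toward a higher number. Compound 4 is estimated at 350 nM, within 150 nM to 900 nM.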

Compound 4, inhibition constant: 3490 nM
Beside the measured number, compound 4's estimate is 10-fold (1.00 log units) below it; measured number above the stated range.
By their numbers in this assay, from the lowest: compound 3; then compound 1; then compound 2; then compound 4.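

In this assay, methoxy in place of hydrogen on this aromatic carbon, ortho to a methoxy group and meta to a large group, is far from a neutral addition: a 15-fold higher number from compound 1 to compound 4 (1.18 log units; beyond the scatter) is large and beyond the scatter. Among these compounds, this single-place change, 4-methoxyphenyl to 3,4-dimethoxyphenyl, gives the first direct reading at this ring position, and the number rises. No measured evidence on the compounds shown accounts for this step.

Open, from the compounds shown here alone, is whether fluoro or hydroxy on the same aromatic carbon would give a step of similar size. Also open, going by these compounds, is whether methoxy at this position gives a comparable step on a shorter or longer chain.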